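The compounds below may be only part of what the source reports. "The series", "measured", "known", "first", "only" and "open" are said of these compounds alone.

Measured compounds so far:

Compound 1, `CCC(=O)Nc1cccc(Oc2nc(Nc3ccc(N4CCCCC4)cc3)ncc2Cl)c1`: in an assay on isolated protein for inhibition of NUAK family SNF1-like kinase 1 (Homo sapiens), read by ADP-Glo, with a stated time of 60 min, tested at 10 uM, in the presence of a further agent that is not named here (a lower number here means less inhibition, a higher number more inhibition at the concentration tested (going by the name of the read-out)), compound 1 gives 86%.
Compound 2, `CCC(=O)Nc1cccc(Oc2nc(Nc3ccc(N(CC)CC)cc3)ncc2Cl)c1`: in this assay compound 2 gives 54.4%.

Compound 2 stands lowest of the two numbers. Its nearest neighbour is compound 1, which lies above it by a step that is beyond the usual scatter: a number 31.6 percentage points lower from compound 1 to compound 2 (beyond the scatter).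

Compound 3, `CCC(=O)Nc1cccc(Oc2nc(Nc3ccc(N4CCC(C)CC4)cc3)ncc2Cl)c1`, has not yet been measured in this assay. It differs from compound 2 in one place: 4-methylpiperidin-1-yl in place of diethylamino on an aromatic carbon.

Among the compounds with values here, only one measured step bears on this change, namely a number 31.6 percentage points lower from compound 1 to compound 2 (beyond the scatter), in which piperidin-1-yl gave way to diethylamino and the inhibition dropped sharply. The step from compound 2 to compound 3 runs the other way, putting a six-membered non-aromatic ring back in place of the open diethylamino group, now carrying a methyl. A rise beyond the scatter is therefore expected, close in size to the earlier drop, though the methyl adds some uncertainty. For compound 3 the expected step is a number 25.6 percentage points higher from compound 2 to compound 3 (beyond the scatter). Compound 3 is estimated at 80%, with a likely range from 60% to 95%.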

Compound 3, a percentage reported as inhibition, at one concentration (the size of the read-out at that concentration, not a potency): 13.4%
Estimate against measurement, compound 3: 66.6 percentage points above, and the stated range ends above it.
By their numbers in this assay, from the lowest: compound 3; then compound 2; then compound 1.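

In this assay, the step for methyl in place of hydrogen on a saturated ring carbon is a number 72.6 percentage points lower from compound 1 to compound 3 (beyond the scatter), so this position responds strongly to one added methyl on the ring. The presence of a six-membered non-aromatic ring therefore does not by itself decide the outcome: the change from diethylamino to 4-methylpiperidin-1-yl gives a number 41 percentage points lower from compound 2 to compound 3 (beyond the scatter), and the open diethylamino group lies between the plain piperidin-1-yl ring and its methylated form. No measurement at hand explains this sharp loss of inhibition.

The three compounds leave open whether the drop is particular to methyl or also follows with another group in its place, such as an ethyl, a hydroxyl or a fluorine. They also leave open how other rings would compare with piperidin-1-yl on this aromatic carbon, for example pyrrolidin-1-yl or morpholin-4-yl.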